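A few compounds are considered here, and "the series" means these few. Any claim that something is new, unique, unknown or untested is made for them only; others in the source may bear on it.

Measured so far:
compound 1 `CNc1nc(=O)ccn1[C@@H]1O[C@H](COP(=O)(O)O)[C@@H](O)[C@H]1O` – > 100000 nM
compound 2 `O=c1ccn([C@@H]2O[C@H](COP(=O)(O)O)[C@@H](O)[C@H]2O)c(SCCc2ccccc2)n1` – > 100000 nM

In an in vitro functional assay on 1321-N1 cells for agonist activity at P2Y purinoceptor 6 (Homo sapiens), read by scintillation proximity assay and inositol phosphate accumulation (a higher number here means that more compound is needed for the effect, a lower number that less compound is needed), compound 1 gives > 100000 nM, which is a limit of the assay and not a number. Compound 2 in this assay also gives only a limit, > 100000 nM. Among the compounds with values here, the single measured step, a step that the two limits leave unreadable from compound 1 to compound 2, is thus unreadable, both values sitting at the limit of > 100000 nM in this assay, at which 2 of the 2 values shown sit, and it concerns a different group in any case. Compound 3 `CNc1nc(=O)ccn1[C@@H]1O[C@H](COP(=O)(O)OP(=O)(O)O)[C@@H](O)[C@H]1O` differs from compound 1 by a group of 4 heavy atoms (3 oxygen, 1 phosphorus; no ring) in place of a hydrogen atom, on an oxygen. Within the data shown here, no measured step bears on this change, so the direction and size of the step are estimated as an at least 33-fold lower number from compound 1 to compound 3 (1.52 log units; beyond the scatter) from the structural change alone. Compound 3 is expected to give about 3000 nM in this assay, within 300 nM to 50000 nM.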

Compound 3, half-maximal effective concentration: > 100000 nM
Compound 3: a limit, no number; the forecaster's own chance of this, stated with the estimate: 30%; middle value at least 33-fold (1.52 log units) from the limit.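

The values for compound 1 and compound 3 are both limits of the assay and not numbers, so no step between them can be read: the limit of > 100000 nM in this assay, at which 3 of the 3 values shown sit.

The compounds shown leave open which change to the shared core, if any, would give a readable number in this assay.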